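Acyl change on compound 2

This account rests on a few compounds, and the source may have more. Where it says the series, first, only, none or still open, it means among the compounds named here.

compound 1 `C/C=C/C(=O)N(Cc1ccc(OC)c([N+](=O)[O-])c1)c1cc(OC)c(OC)c(OC)c1` - 590 nM
compound 2 `COc1ccc(CN(C(=O)C=C(C)C)c2cc(OC)c(OC)c(OC)c2)cc1O` - 320 nM
compound 3 `COc1ccc(CNc2cc(OC)c(OC)c(OC)c2)cc1F` - 39700 nM

In a functional assay on MGC-803 cells (Homo sapiens) for inhibition, read by MTT assay, with a stated time of 48 h (on this read-out lower numbers stand for stronger inhibition and higher numbers for weaker inhibition), compound 2 (320 nM) lies within the scatter of compound 1 (590 nM), while compound 3 (39700 nM) gives a far higher number, beyond the scatter. Compound 4 `COc1ccc(CN(C(=O)CCCl)c2cc(OC)c(OC)c(OC)c2)cc1O` differs from compound 2 in one place: 2-chloroethyl in place of 2-methylprop-1-en-1-yl on a carbonyl carbon. Among the measured compounds shown here, no measured pair isolates this change, so the expectation in this assay is only a step within the scatter or slightly beyond it, toward a higher number. The estimated change is a 1.9-fold higher number from compound 2 to compound 4 (0.27 log units; within the scatter) at its middle. For compound 4 an estimated 600 nM is expected, within a range of 130 nM to 2800 nM on current data.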

Compound 4, half-maximal inhibitory concentration: 140 nM
The estimate for compound 4 lay 4.3-fold (0.63 log units) above the measured number; the measured number falls inside the stated range.
By their numbers in this assay, from the lowest: compound 4; then compounds 2 and 1 (each within the scatter of the next); then compound 3.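

In this assay the carbonyl carbon on the amide-type nitrogen accepts 2-chloroethyl in place of 2-methylprop-1-en-1-yl, with a 2.3-fold lower number from compound 2 to compound 4 (0.36 log units; beyond the scatter) as a modest step. This is the only single-place step among the compounds shown, and it indicates that neither the double bond nor the 2-methylprop-1-en-1-yl group is required at this position to retain inhibition. Nothing shown bears on the reason for the step.

From the compounds shown here alone, whether the step goes with the chlorine or with the saturated chain stays open: ethyl, 2-aminoethyl or 3-chloropropyl on the same carbonyl carbon would tell these apart.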